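The source may hold more compounds than are shown below. What is called first, only, known or untested is meant among the compounds shown, and "the series" means these compounds.

Going by the values given here, compound 1 `NC(=S)N/N=C1/C(=O)N(CN2CCN(c3ccnc4cc(Cl)ccc34)CC2)c2cccc(Cl)c21` is one of three compounds measured in an ADME assay on MCF-10A cells (Homo sapiens) for cytotoxicity, read by sulforhodamine B assay, with a stated time of 48 h (a lower number here means a stronger inhibitor of growth, a higher number a weaker inhibitor of growth), where compound 1 gives 19800 nM. Compound 3 `NC(=S)N/N=C1/C(=O)N(CN2CCN(c3ccnc4cc(C(F)(F)F)ccc34)CC2)c2cccc(Cl)c21` differs from compound 1 by trifluoromethyl in place of chloro on an aromatic carbon, and in this assay compound 3 gives 51700 nM, a step of a 2.6-fold higher number from compound 1 to compound 3 (0.42 log units; beyond the scatter). Compound 2 `NC(=S)N/N=C1/C(=O)N(CN2CCN(c3ccnc4cc(Cl)ccc34)CC2)c2cc(Cl)ccc21` is built from the same atoms as compound 1 joined differently; the difference between the two cores is not broken down here. In this assay compound 2 gives 64600 nM. Compound 4 `NC(=S)N/N=C1/C(=O)N(CN2CCN(c3ccnc4cc(C(F)(F)F)ccc34)CC2)c2cc(Cl)ccc21` differs from compound 2 by trifluoromethyl in place of chloro on an aromatic carbon, the same change as that from compound 1 to compound 3. Because the earlier step was a 2.6-fold higher number from compound 1 to compound 3 (0.42 log units; beyond the scatter), a similar step is expected here, estimated as a 2.3-fold higher number from compound 2 to compound 4 (0.37 log units; beyond the scatter). Compound 4 is therefore estimated at 150000 nM, between 70000 nM and 320000 nM.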

Compound 4, concentration for 50% growth inhibition: 38800 nM
Compound 4: the middle estimate sits 3.9-fold (0.59 log units) above what was measured, and the stated range ends above it.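

In this assay, trifluoromethyl in place of chloro on the core of compound 2 gives a 1.7-fold lower number from compound 2 to compound 4 (0.22 log units; within the scatter), a step too small to read as a real difference. The same swap does not carry over at the same size from one core to the other in this assay: the same change on two cores in this assay, a 2.6-fold higher number (0.42 log units; beyond the scatter) from compound 1 to compound 3 and a 1.7-fold lower number (0.22 log units; within the scatter) from compound 2 to compound 4, 4.3-fold (0.64 log units) apart, beyond the scatter of two such steps. Going by these compounds alone, with only one pair on each core, this warns against using a step on one core to estimate it on the other, but it does not show why the cores differ or how the swap would behave on a further core.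

The compounds shown leave open how a smaller group such as fluoro, or a methoxy or an amine on that aromatic carbon, would behave on each core. They also leave open whether any such group would give steps that agree between the two cores.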